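The source may report more compounds than this note shows. Statements on the series, on what has been measured and on what is new or still open speak of the compounds shown alone.

Compound 3 `[O-][S+](Cc1ccc(Cl)s1)C(c1ccccc1)c1ccccc1` gives 12800 nM in an assay on HEK293 cells for inhibition of sodium-dependent dopamine transporter (Homo sapiens), read by scintillation counting, with stated times of 5 min and 1 min; on this read-out higher numbers stand for weaker inhibition and lower numbers for stronger inhibition. Within the series it holds the second highest number of the three: compound 1 `Cc1nc(O)cc(C[S+]([O-])C(c2ccccc2)c2ccccc2)n1` gives 3100 nM, and the step of a 4.1-fold higher number from compound 1 to compound 3 (0.62 log units; beyond the scatter) is beyond the scatter; compound 2 `CC(C)c1nnsc1C[S+]([O-])C(c1ccccc1)c1ccccc1` gives 69100 nM, and the step of a 5.4-fold lower number from compound 2 to compound 3 (0.73 log units; beyond the scatter) is likewise beyond the scatter. The direct step of a 22-fold higher number from compound 1 to compound 2 (1.35 log units; beyond the scatter) frames the whole range seen so far.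

Compound 4 `Cc1noc(C[S+]([O-])C(c2ccccc2)c2ccccc2)n1` is not yet measured. The change from compound 3 is 3-methyl-1,2,4-oxadiazol-5-yl in place of 5-chlorothiophen-2-yl on a saturated chain carbon bound to a sulfur. Both measured steps at this position bear on it: swapping the 6-hydroxy-2-methylpyrimidin-4-yl group for 5-chlorothiophen-2-yl raised the number modestly, while swapping 4-isopropyl-1,2,3-thiadiazol-5-yl for 5-chlorothiophen-2-yl lowered it modestly. The 3-methyl-1,2,4-oxadiazol-5-yl group resembles the thiadiazole in ring type yet carries a methyl rather than an isopropyl, so the expectation is a modest rise, a 1.7-fold higher number from compound 3 to compound 4 (0.24 log units; within the scatter), with wide uncertainty. Compound 4 is thus estimated at 22000 nM in this assay, in a range from 6000 nM to 70000 nM.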

Compound 4, half-maximal inhibitory concentration: 56700 nM
The estimate for compound 4 lay 2.6-fold (0.41 log units) below the measured number, within the range that was stated.
By their numbers in this assay, from the lowest: compound 1; then compound 3; then compounds 4 and 2 (each within the scatter of the next).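

The step of a 4.4-fold higher number from compound 3 to compound 4 (0.65 log units; beyond the scatter) shows that 3-methyl-1,2,4-oxadiazol-5-yl, on a saturated chain carbon bound to a sulfur, does not hold the level of 5-chlorothiophen-2-yl, although both groups count 6 heavy atoms; in this pair, equal heavy-atom count does not give equal numbers. The step of a 1.2-fold lower number from compound 2 to compound 4 (0.09 log units; within the scatter) stays within the scatter, so 3-methyl-1,2,4-oxadiazol-5-yl and 4-isopropyl-1,2,3-thiadiazol-5-yl cannot be ordered, while the step of an 18-fold higher number from compound 1 to compound 4 (1.26 log units; beyond the scatter) leaves compound 1 with the lowest number of the four. No supporting measurement bears on why these groups differ.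

Which part of 6-hydroxy-2-methylpyrimidin-4-yl goes with the lower number stays open, since the hydroxy and the methyl never change alone. As far as these compounds go, how an amine, a carboxylic acid or a longer chain would read at this position also remains unknown.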